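The compounds below may be only part of what the source reports. "The series", "measured", "known", "first", "only" and "open" are said of these compounds alone.

Going by the values given here, in a functional assay on HepG2 cells (Homo sapiens) for antiproliferative activity, read by MTT assay, with a stated time of 48 h (a lower number here means a stronger inhibitor, a higher number a weaker inhibitor), two compounds with the same core have numbers so far. Compound 1 `COc1ccc(-c2c(Nc3ccc(F)cc3)c3ccc(O)cc3oc2=O)cc1` gives 65600 nM, and compound 2 `COc1ccc(-c2c(Nc3ccc(C)cc3)c3ccc(O)cc3oc2=O)cc1` gives 88300 nM. These two values lie within the usual scatter of each other, so compound 2 cannot be told apart from compound 1 on this evidence.

Compound 3 `COc1ccc(-c2c(Nc3ccc(NC(C)=O)cc3)c3ccc(O)cc3oc2=O)cc1` keeps the shared core and changes one group of compound 2: acetamido in place of methyl on an aromatic carbon. This puts acetamido in place of methyl on an aromatic carbon, para to a large group.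

Among the compounds with values here, only one measured step bears on this change, a swap of methyl for fluoro at that same place: a 1.3-fold higher number from compound 1 to compound 2 (0.13 log units; within the scatter). Within the data shown here, that step stayed within the scatter, but it is a thin guide, since the entering acetamido is larger than either fluoro or methyl and no measured compound carries an amide there. The expected step in this assay is a 1.3-fold lower number from compound 2 to compound 3 (0.10 log units; within the scatter), which means no change beyond the scatter is expected and no firm direction can be given. For compound 3 the estimated value is 70000 nM, with an expected range from 25000 nM to 180000 nM.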

Compound 3, half-maximal inhibitory concentration: > 100000 nM
Compound 3: only a limit was reported; the forecaster's own chance of this, stated with the estimate: 20%; middle value at least 1.4-fold (0.15 log units) away from the limit.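

In this assay compound 3 is reported only as a limit and not as a number: (the limit of > 100000 nM in this assay, at which 1 of the 3 values shown sits). The two steps that reach it are therefore floors and not full sizes (an at least 1.1-fold higher number from compound 2 to compound 3 (0.05 log units; that floor lies within the scatter); an at least 1.5-fold higher number from compound 1 to compound 3 (0.18 log units; that floor lies within the scatter)), and both floors lie within the scatter, so the true size of either change cannot be read. Even so, this position has now been tested with 4-acetamidophenyl, a larger group than the 4-methylphenyl of compound 2 and one that brings a hydrogen-bond donor and a hydrogen-bond acceptor, and the result gives no sign of a lower number, which the small swap between fluoro and methyl could not show.

From the compounds shown here alone, how far the number really rises with acetamido stays open, and so does whether the amide as such or simply the extra atoms set this result. An amine or a carboxylic acid on the same aromatic carbon, or a longer chain on the amide, would be needed to separate those two readings and to show whether any group here can give a clearly lower number.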